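Swapping Cyclopropyl for Methyl on a Fused Core

The source may hold more compounds than are shown below. What is called first, only, known or untested is meant among the compounds shown, and "the series" means these compounds.

Of the compounds shown here, three have been measured in a functional assay on CHO cells for antagonist activity at metabotropic glutamate receptor 5 (Homo sapiens), read by calcium flux; a lower number here means a stronger inhibitor, a higher number a weaker inhibitor. Compound 1 `Cc1c(C(C)OC(=O)Nc2ccccc2Cl)oc2ncnn12` gives 501 nM in this assay. Compound 2 `Cc1c(C(C)OC(=O)Nc2ccc(Cl)c(Cl)c2)oc2ncnn12` gives 5010 nM. Compound 3 `Cc1c(C(C)OC(=O)Nc2ccccc2)oc2nc(C3CC3)nn12` gives 12.6 nM, the lowest number of the three; its gap to compound 1 and its larger gap to compound 2 are both beyond the scatter. Compound 3 is the only one carrying a cyclopropyl on the shared core, and also the only one with an unsubstituted phenyl on the carbamate, so its advantage cannot be assigned to either feature on its own.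

Compound 4 `Cc1nc2oc(C(C)OC(=O)Nc3ccccc3)c(C)n2n1` has not been measured. It differs from compound 3 in one way: methyl in place of cyclopropyl on an aromatic carbon. Going by the values given here, no measured pair shows this change by itself, so its effect is uncertain. A small shrinking of a group on the core seems most likely to cost a little activity rather than a lot, so compound 4 is expected to be a somewhat weaker inhibitor than compound 3, with an estimated step of a 3.2-fold higher number from compound 3 to compound 4 (0.50 log units; beyond the scatter). Compound 4 is therefore estimated at 40 nM, with a likely range from 10 nM to 160 nM.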

Compound 4, half-maximal inhibitory concentration: 39.8 nM
For compound 4 the middle estimate is 1.0-fold (0.00 log units) above the measured one, and the stated range covers the measured number.
By their numbers in this assay, from the lowest: compound 3; then compound 4; then compound 1; then compound 2.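

Going by these compounds alone, replacing cyclopropyl with methyl on this aromatic carbon gives the first comparison that differs in only one place: in this assay, the change produces a 3.2-fold higher number from compound 3 to compound 4 (0.50 log units; beyond the scatter). This ties part of the low number of compound 3 to the cyclopropyl itself, while the modest size of the step shows that methyl at this position still leaves compound 4 an active inhibitor. No accompanying measurement explains the step.

On these data alone, whether an amine, an ethyl group or a longer chain on this carbon would give a lower or higher number remains open. It is also unknown whether the same step would appear with a chlorine-bearing phenyl on the carbamate, as in compound 1 and compound 2, in place of the unsubstituted phenyl.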